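The source may report more compounds than this note shows. Statements on the series, on what has been measured and on what is new or still open speak of the compounds shown alone.

Measured compounds and values in a functional assay on SMMC-7721 cells (Homo sapiens) for cytotoxicity, read by MTT assay, with a stated time of 4 days; a higher number here means a weaker inhibitor, a lower number a stronger inhibitor:

compound 1, `C=C1C(=O)[C@]23C[C@@]1(O)CC[C@H]2c1ccc(OS(=O)(=O)c2ccc(C)cc2)c(C)c1[C@@H]3Cn1cc(-c2ccccn2)nn1`, 2830 nM
compound 2, `C=C1C(=O)[C@]23C[C@@]1(O)CC[C@H]2c1ccc(OS(=O)(=O)c2ccc(C)cc2)c(C)c1[C@@H]3Cn1cc(-c2ccc(Cl)cc2)nn1`, 6180 nM
compound 3, `C=C1C(=O)[C@]23C[C@@]1(O)CC[C@H]2c1ccc(OS(=O)(=O)c2ccc(C)cc2)c(C)c1[C@@H]3Cn1cc(-c2ccc(F)cc2)nn1`, 4280 nM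

Compound 3 sits with the other two: its separation from compound 2 and from compound 1 is each within the scatter, so the three cannot be ranked against one another on these numbers alone. For the measured compounds named here, only the step of a 2.2-fold higher number from compound 1 to compound 2 (0.34 log units; beyond the scatter) is beyond the scatter; the steps of a 1.5-fold higher number from compound 1 to compound 3 (0.18 log units; within the scatter) and a 1.4-fold lower number from compound 2 to compound 3 (0.16 log units; within the scatter) are not.

Compound 4 is `C=C1C(=O)[C@]23C[C@@]1(O)CC[C@H]2c1ccc(OS(=O)(=O)c2ccc(C)cc2)c(C)c1[C@@H]3Cn1cc(-c2ccc(C)cc2)nn1`. Its difference from compound 3 is methyl in place of fluoro on an aromatic carbon. Going by the values given here, no measured pair shows a methyl entering in place of a fluoro, so the nearest guide is the exchange of one para substituent on the same phenyl ring for another, which is the step of a 1.4-fold lower number from compound 2 to compound 3 (0.16 log units; within the scatter), and that step stayed within the scatter. On that basis the step of a 1.1-fold higher number from compound 3 to compound 4 (0.05 log units; within the scatter) is expected to be small as well, with no direction supported beyond the scatter. Among the compounds with values here, compound 4 is therefore estimated at 4800 nM in this assay, with a range from 2200 nM to 10500 nM, the range set wide because the only directly related step, a 1.4-fold lower number from compound 2 to compound 3 (0.16 log units; within the scatter), rests on a single pair.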

Compound 4, half-maximal inhibitory concentration: 4410 nM
Estimate against measurement, compound 4: 1.1-fold (0.04 log units) above, within the range that was stated.
By their numbers in this assay, from the lowest: compounds 1, 3, 4 and 2 (each within the scatter of the next, the first and the last beyond it).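

In this assay, for the compounds shown here, methyl is the first group on this aromatic carbon that is not a halogen, and it leaves the number unmoved against both halogens: methyl in place of fluoro gives a 1.0-fold higher number from compound 3 to compound 4 (0.01 log units; within the scatter), and methyl in place of chloro gives a 1.4-fold lower number from compound 2 to compound 4 (0.15 log units; within the scatter). Across fluoro, chloro and methyl, then, the substituent on this carbon of the phenyl ring produces no step beyond the scatter, although the three compounds are still only a small set. Going by these compounds alone, exchanging the whole aryl group for 4-methylphenyl in place of pyridin-2-yl gives a 1.6-fold higher number from compound 1 to compound 4 (0.19 log units; within the scatter), which leaves a 2.2-fold higher number from compound 1 to compound 2 (0.34 log units; beyond the scatter) as the only step beyond the scatter, and nothing available offers an explanation for this flat response.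

Going by these compounds, it remains open whether a group of a different kind on this carbon, such as an amine, a carboxylic acid or a longer chain, would give a step beyond the scatter. On these data alone, it is also open whether the flat response holds on the other rings of the shared core, or whether the shift seen with the chloro group is more than a single pair can support.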